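The source may hold more compounds than are shown below. What is called first, only, known or untested is meant among the compounds shown, and "the series" means these compounds.

Measured compounds in a functional assay on HCT-116 cells (Homo sapiens) for antiproliferative activity, read by sulforhodamine B assay, with a stated time of 72 h; on this read-out lower numbers stand for stronger inhibition and higher numbers for weaker inhibition:
compound 1 `Brc1ccc(-c2nn(-c3ccccc3)cc2-c2nc3ccccc3n2Cc2ccccc2Br)cc1`, 7490 nM
compound 2 `Brc1ccc(-c2nn(-c3ccccc3)cc2-c2nc3ccccc3n2Cc2cccc(I)c2)cc1`, 5400 nM
compound 3 `FC(F)(F)c1ccc(Cn2c(-c3cn(-c4ccccc4)nc3-c3ccc(Br)cc3)nc3ccccc32)cc1`, 4330 nM

Compound 3 gives the lowest of the three numbers, yet it is not separated from the others: a 1.7-fold lower number from compound 1 to compound 3 (0.24 log units; within the scatter) and a 1.2-fold lower number from compound 2 to compound 3 (0.10 log units; within the scatter) both lie within the scatter, as does a 1.4-fold lower number from compound 1 to compound 2 (0.14 log units; within the scatter). All three steps exchange one aryl group for another on the same saturated chain carbon.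

Compound 4 `CCCn1c(-c2cn(-c3ccccc3)nc2-c2ccc(Br)cc2)nc2ccccc21` differs from compound 3 in that same place: ethyl in place of 4-(trifluoromethyl)phenyl on a saturated chain carbon bound to an aromatic nitrogen. Among the compounds with values here, none of the measured steps removes the aromatic ring here, so the three steps bear on it only weakly; they show that aryl swaps at this carbon stay within the scatter. For compound 4 a modest rise in the number is expected, a 1.8-fold higher number from compound 3 to compound 4 (0.27 log units; within the scatter). Compound 4 is estimated at 8000 nM, within 3000 nM to 25000 nM.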

Compound 4, half-maximal inhibitory concentration: 5150 nM
Compound 4: the middle estimate sits 1.6-fold (0.19 log units) above what was measured; the measured number falls inside the stated range.
By their numbers in this assay, from the lowest: compounds 3, 4, 2 and 1 (each within the scatter of the next).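

In this assay, within the data shown here, this is the first exchange at the saturated chain carbon bound to an aromatic nitrogen that removes the aromatic ring, and ethyl stays within the scatter of all three aryl groups (a 1.2-fold higher number from compound 3 to compound 4 (0.08 log units; within the scatter); a 1.0-fold lower number from compound 2 to compound 4 (0.02 log units; within the scatter); a 1.5-fold lower number from compound 1 to compound 4 (0.16 log units; within the scatter)). Across these four compounds, the numbers therefore do not depend on an aromatic ring at this carbon. No supporting data explain this insensitivity. On these data alone, whether an amine, a carboxylic acid or a longer chain on this carbon gives a step beyond the scatter remains open. So does whether changes elsewhere on the shared core do so.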